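A few compounds are considered here, and "the series" means these few. Any claim that something is new, unique, unknown or untested is made for them only; others in the source may bear on it.

Compound 1 `COc1ccc(/C=C/C[C@@H]2C[C@@H]([C@@H](OC)c3ccc(OC)c(OC)c3)CO[C@H]2c2ccc(OC)c(OC)c2)cc1OC` opens this set. In a functional assay on HeLa cells (Homo sapiens) for cytotoxicity, read by WST assay, with a stated time of 48 h (on this read-out higher numbers stand for weaker inhibition and lower numbers for stronger inhibition), compound 1 reaches only > 100000 nM, which is a limit of the assay and not a number. Compound 2 `O=[N+]([O-])c1cccc(/C=C/C[C@H]2C[C@@H]([C@@H](O)c3ccccc3)CO[C@@H]2c2ccccc2)c1` is the other measured member, and in this assay compound 2 gives 7850 nM. Among the compounds with values here, that is the only number in hand. The other value, that of compound 1, sits at the limit of > 100000 nM in this assay, at which 1 of the 2 values shown sits. Compound 3 `O=[N+]([O-])c1ccccc1/C=C/C[C@H]1C[C@@H]([C@@H](O)c2ccccc2)CO[C@@H]1c1ccccc1` differs from compound 2 in one place (2-nitrophenyl in place of 3-nitrophenyl on a double-bonded chain carbon bound to a double-bonded chain carbon). Within the data shown here, no measured pair shows such a change, so for compound 3 no step beyond the usual scatter is expected in either direction a 1.1-fold higher number from compound 2 to compound 3 (0.06 log units; within the scatter). Compound 3 is therefore estimated at 9000 nM, likely between 3000 nM and 30000 nM.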

Compound 3, half-maximal inhibitory concentration: 11800 nM
For compound 3 the middle estimate is 1.3-fold (0.12 log units) below the measured one; the range from low to high includes it.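

Within the data shown here, this is the first measured pair in this assay that differs in one place: 2-nitrophenyl in place of 3-nitrophenyl on a double-bonded chain carbon bound to a double-bonded chain carbon gives a 1.5-fold higher number from compound 2 to compound 3 (0.18 log units; within the scatter). On this read-out, the two nitrophenyl groups therefore cannot be told apart at this position. Nothing shown here bears on the reason for this result.

Going by these compounds, what stays open is whether 4-nitrophenyl would behave the same way. On these data alone, it is also open whether a phenyl ring carrying an amine or a carboxylic acid instead of the nitro group would shift the number beyond the scatter.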